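Quinolone Carboxamide Amides: Pyridyl for Phenyl, Liver Clearance

The source may hold more compounds than are shown below. What is called first, only, known or untested is meant among the compounds shown, and "the series" means these compounds.

compound 1 `Cn1cc(C(=O)Nc2cnc(-c3ccccc3)c(C(F)(F)F)c2)c(=O)c2ccccc21`: < 14 uL/min
compound 2 `Cn1cc(C(=O)Nc2ccc(-c3ccccc3)c(C(F)(F)F)c2)c(=O)c2ccccc21`: < 14 uL/min

In an ADME assay on microsomes from liver (Rattus norvegicus) for metabolic stability, with a stated time of 30 min (on this read-out lower numbers stand for slow clearance and higher numbers for fast clearance), compound 1 `Cn1cc(C(=O)Nc2cnc(-c3ccccc3)c(C(F)(F)F)c2)c(=O)c2ccccc21` returns < 14 uL/min, which is a limit of the assay rather than a number. Compound 2 `Cn1cc(C(=O)Nc2ccc(-c3ccccc3)c(C(F)(F)F)c2)c(=O)c2ccccc21` is likewise reported at a limit, giving < 14 uL/min in this assay. Both values sit at the limit of < 14 uL/min in this assay, at which 2 of the 2 values shown sit. On the numbers shown, compound 2 stands level with compound 1, and neither can be ranked above the other.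

Compound 3 `Cn1cc(C(=O)Nc2ccc(-c3cccnc3)c(C(F)(F)F)c2)c(=O)c2ccccc21` differs from compound 2 by pyridin-3-yl in place of phenyl on an aromatic carbon. Among the measured compounds shown here, no measured step accompanies this change; the expected step that the limit leaves unreadable from compound 2 to compound 3 is none beyond the usual scatter. Compound 3 is therefore estimated at 10 uL/min, within 4 uL/min to 25 uL/min, and will most likely again come back as a limit.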

Compound 3, intrinsic clearance in a liver preparation (reported as CLH), per the amount of preparation that the assay uses in the Rattus norvegicus assay: 18 uL/min
For compound 3 the middle estimate is 1.8-fold (0.26 log units) below the measured one; low and high end bracket the measured number.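

Among the compounds shown here, in the Rattus norvegicus assay, pyridin-3-yl in place of phenyl gives a readable number at this position, where the earlier compounds gave only a limit, but the step can be stated only as an at least 1.2-fold higher number from compound 2 to compound 3 (0.10 log units; that floor lies within the scatter). In a physicochemical assay for solubility, in simulated intestinal fluid, at pH 7.4 (on this read-out lower numbers stand for lower solubility and higher numbers for higher solubility), compound 2 gives 11 ug/mL and compound 3 gives 6.7 ug/mL, a difference that stays within the usual scatter.

From the compounds shown here alone, the true size of the step in the Rattus norvegicus assay stays open. So does how a pyridin-4-yl or a piperidine at this position would read in either assay.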